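Swapping Trifluoromethyl for Chloro on Compound 1

The source may report more compounds than this note shows. Statements on the series, on what has been measured and on what is new or still open speak of the compounds shown alone.

Measured in an ADME assay on microsomes from liver (Mus musculus) for metabolic stability, read by LC-MS, using NADPH, with a stated time of 10 min, tested at 10 uM; on this read-out lower numbers stand for a shorter-lived compound and higher numbers for a longer-lived compound:
- compound 1 `Nc1ncnc2c1c(Oc1cc(C(F)(F)F)ccn1)nn2C1CC1` gives > 2.41 h (a limit, not a number)
- compound 2 `CO[C@H]1CC[C@@H](n2nc(Oc3cc(C(F)(F)F)ccn3)c3c(N)ncnc32)CC1` gives 0.0333 h
- compound 3 `Nc1ncnc2c1c(Oc1cc(C(F)(F)F)ccn1)nn2C1CCC(O)C1` gives 0.3 h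

Compound 1 stands at the limit of > 2.41 h in this assay, at which 1 of the 3 values shown sits. Its true half-life is therefore not known. Compound 4 `Nc1ncnc2c1c(Oc1cc(Cl)ccn1)nn2C1CC1` keeps the cyclopropyl of compound 1 and changes in one place, with chloro in place of trifluoromethyl on an aromatic carbon.

The measured steps all concern the group on an aromatic nitrogen. The large one is an at least 72-fold lower number from compound 1 to compound 2 (1.85 log units; beyond the scatter). The smaller ones are an at least 8.0-fold lower number from compound 1 to compound 3 (0.90 log units; beyond the scatter) and a 9.0-fold higher number from compound 2 to compound 3 (0.95 log units; beyond the scatter). None of them touches the aromatic carbon that changes in compound 4, so they give no direct size for this swap. They show only that this assay responds strongly to changes on the nitrogen, which stays the same here. No step beyond the scatter is therefore expected. The expected result is an at least 1.0-fold lower number from compound 1 to compound 4 (0.03 log units; that floor lies within the scatter). The estimated half-life of compound 4 is 2.2 h. The expected range for compound 4 runs from 0.7 h to 5 h.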

Compound 4, half-life: 0.233 h
The estimate for compound 4 lay 9.4-fold (0.98 log units) above the measured number, and the stated range ends above it.
By their numbers in this assay, from the lowest: compound 2; then compounds 4 and 3 (each within the scatter of the next). At a limit, above all of these: compound 1.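

In this assay, among these compounds, chloro in place of trifluoromethyl gives an at least 10-fold lower number from compound 1 to compound 4 (1.01 log units; beyond the scatter), so the aromatic carbon opposite the ring nitrogen matters as well as the group on the aromatic nitrogen, the only place that differs among the earlier compounds. Keeping the cyclopropyl is therefore not enough to keep the long half-life of compound 1, which goes with trifluoromethyl at this carbon. The full size of this step remains unknown because compound 1 gives only a limit, not a number: the limit of > 2.41 h in this assay, at which 1 of the 4 values shown sits.

On these data alone, only trifluoromethyl and chloro appear at this carbon, so it remains open where a methyl, a methoxy or a nitrile would fall. Chloro is also paired only with cyclopropyl, leaving open how it would behave with 3-hydroxycyclopentyl or 4-methoxycyclohexyl on the aromatic nitrogen.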